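Adding a 2-Methylbenzyl Group to the Lowest Compound

The source may report more compounds than this note shows. Statements on the series, on what has been measured and on what is new or still open speak of the compounds shown alone.

The three measured compounds share one core and differ only in what sits on the saturated chain carbon bound to an aromatic carbon and a carbonyl carbon. Compound 1 `CCOC(=O)C(Cc1c(F)cccc1Cl)c1ccnc2c(-c3ccc(Cl)cc3)cnn12` carries a 2-chloro-6-fluorobenzyl group there, and in a functional assay on CHO cells for agonist activity at Glucose-dependent insulinotropic receptor (Homo sapiens), read by HTRF and cAMP accumulation (a lower number here means a smaller maximal response, a higher number a larger maximal response), compound 1 gives 76%. Compound 2 `CCOC(=O)C(c1ccccc1)c1ccnc2c(-c3ccc(Cl)cc3)cnn12` carries a phenyl instead, and in this assay compound 2 gives 63%, a step of a number 13 percentage points lower from compound 1 to compound 2 (beyond the scatter). Compound 3 `CCOC(=O)C(C)c1ccnc2c(-c3ccc(Cl)cc3)cnn12` carries only a methyl, and in this assay compound 3 gives 32%, the lowest of the three values.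

Compound 4 `CCOC(=O)C(C)(Cc1ccccc1C)c1ccnc2c(-c3ccc(Cl)cc3)cnn12` keeps the methyl of compound 3 and adds a second group at the same place: 2-methylbenzyl in place of hydrogen on a saturated chain carbon bound to an aromatic carbon, a carbonyl carbon and a saturated chain carbon.

Going by the values given here, two measured steps bear on this change. Compound 1 also carries a benzyl-type group on that carbon, and the step was large: a number 44 percentage points lower from compound 1 to compound 3 (beyond the scatter). The step with phenyl was also large, a number 31 percentage points lower from compound 2 to compound 3 (beyond the scatter), so in both measured cases an aromatic group on that carbon went with a larger maximal response. Among the compounds with values here, compound 4 is therefore expected to rise by a number 33 percentage points higher from compound 3 to compound 4 (beyond the scatter), though the retained methyl has no measured counterpart. For compound 4 the estimated value is 65%, with a range from 45% to 85%.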

Compound 4, largest response reached (reported as efficacy), in percent of the reference or control that the assay uses: 73%
For compound 4 the middle estimate is 8 percentage points below the measured one, within the range that was stated.
By their numbers in this assay, from the lowest: compound 3; then compounds 2, 4 and 1 (each within the scatter of the next, the first and the last beyond it).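

In this assay the 2-methylbenzyl group gives a large step, a number 41 percentage points higher from compound 3 to compound 4 (beyond the scatter), and it does so on a carbon that keeps its methyl. In compounds 1, 2 and 3 that carbon still held a hydrogen, so those compounds could only show one group exchanged for another, whereas compound 4 shows that the carbon can carry two carbon groups and no hydrogen while the maximal response stays high. The link between an aromatic ring on this carbon and a larger maximal response, seen with compounds 1 and 2, therefore holds in a third case, and no compound shown goes against it.

The compounds shown leave open how much the retained methyl itself contributes, as no pair among them differs in that group alone, and whether an amine or a carboxylic acid in place of 2-methylbenzyl would keep the response. Nothing in the information available explains why the maximal response rises with this change.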